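This account rests on a few compounds, and the source may have more. Where it says the series, first, only, none or still open, it means among the compounds named here.

The measured compounds and their values in a functional assay on HEK293 cells for positive allosteric modulation of metabotropic glutamate receptor 5 (Homo sapiens), read by FLIPR and calcium flux; a higher number here means that more compound is needed for the effect, a lower number that less compound is needed:

compound 1, `O=C1c2ccc(C#Cc3cccnc3)nc2CCN1C1CCCC1`, gives 748 nM
compound 2, `O=C1c2ccc(C#Cc3cccs3)nc2CCN1C1CCCC1`, gives 12 nM
compound 3, `O=C1c2ccc(C#Cc3cccnc3)nc2CCN1C1CCCCC1`, gives 387 nM

Compound 4, `O=C1c2ccc(C#Cc3cccs3)nc2CCN1C1CCCCC1`, has not yet been measured in this assay.

Two changes run through this set. Within the core of compound 1, the change thiophen-2-yl in place of pyridin-3-yl on a triple-bonded carbon made a step of a 62-fold lower number from compound 1 to compound 2 (1.79 log units; beyond the scatter). The two cores differ by cyclohexyl in place of cyclopentyl on an amide-type nitrogen in a ring, a change whose step was a 1.9-fold lower number from compound 1 to compound 3 (0.29 log units; within the scatter). Compound 4 carries the same change as compound 2, (thiophen-2-yl in place of pyridin-3-yl on a triple-bonded carbon), placed on the core of compound 3; the place line reads word for word the same in both pairs, so this is the same change, not merely the same kind.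

The expectation for compound 4 rests on one earlier step only. Because a 62-fold lower number from compound 1 to compound 2 (1.79 log units; beyond the scatter) lies far beyond the scatter and the place of the change is identical, the step from compound 3 to compound 4 is expected to be about as large, estimated at a 48-fold lower number from compound 3 to compound 4 (1.68 log units; beyond the scatter). Going by the values given here, with only a single precedent, the range is kept broad. Compound 4 is thus estimated at 8 nM in this assay, with a likely span from 3 nM to 25 nM.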

Compound 4, half-maximal effective concentration: 13 nM
Compound 4: middle estimate off by 1.6-fold (0.21 log units), on the low side, within the range that was stated.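

In this assay, thiophen-2-yl in place of pyridin-3-yl on a triple-bonded carbon again gave a large step on the core of compound 3 (a 30-fold lower number from compound 3 to compound 4 (1.47 log units; beyond the scatter)), and this step agrees with the earlier one on the core of compound 1: the same change on two cores in this assay, a 62-fold lower number (1.79 log units; beyond the scatter) from compound 1 to compound 2 and a 30-fold lower number (1.47 log units; beyond the scatter) from compound 3 to compound 4, 2.1-fold (0.32 log units) apart, within the scatter of two such steps. Cyclohexyl in place of cyclopentyl on an amide-type nitrogen in a ring also carried over, with the step on the thiophen-2-yl side (a 1.1-fold higher number from compound 2 to compound 4 (0.03 log units; within the scatter)) staying within the scatter, as it did on the pyridin-3-yl side: the same change on two cores in this assay, a 1.9-fold lower number (0.29 log units; within the scatter) from compound 1 to compound 3 and a 1.1-fold higher number (0.03 log units; within the scatter) from compound 2 to compound 4, 2.1-fold (0.32 log units) apart, within the scatter of two such steps. These four compounds show that the two changes carried over between these cores, but they do not show that either change would carry over to a core differing in any other way.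

From the compounds shown here alone, it remains open what a phenyl or furan-2-yl group would give on the triple-bonded carbon. Also open, going by these compounds, is how an open chain such as isopropyl or a longer chain on the amide-type nitrogen would affect the thiophen-2-yl step.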